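Swapping an Acyl Sulfonamide for a Carboxymethoxy Group

The source may report more compounds than this note shows. Statements on the series, on what has been measured and on what is new or still open speak of the compounds shown alone.

Of the compounds shown here, three built on one shared core have been tested in a functional assay on HEK293 cells for agonist activity at Bile acid receptor (Homo sapiens), read by a luciferase reporter; a higher number here means a larger maximal response, a lower number a smaller maximal response. Compound 1 `CC(C)c1onc(-c2c(Cl)cccc2Cl)c1COc1ccc(N(C)C(=O)c2ccc(C(=O)O)cc2)c(C(F)(F)F)n1` gives 63%. Going by the values given here, compound 2 `CC(C)c1onc(-c2c(Cl)cccc2Cl)c1COc1ccc(N(C)Cc2cccc(C(=O)O)c2)c(C(F)(F)F)n1` gives 58%, and the single change between them, 3-carboxybenzyl in place of (4-carboxyphenyl)carbonyl on a nitrogen on an aromatic ring, brought a number 5 percentage points lower from compound 1 to compound 2 (within the scatter). Compound 3 `CC(C)c1onc(-c2c(Cl)cccc2Cl)c1COc1ccc(N(C)Cc2ccc(C(=O)NS(C)(=O)=O)cc2)c(C(F)(F)F)n1` gives 67% in this assay, a number within the usual scatter of both compound 1 and compound 2, so none of the three can be set apart from the others on these data.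

Compound 4 `CC(C)c1onc(-c2c(Cl)cccc2Cl)c1COc1ccc(N(C)Cc2ccc(OCC(=O)O)cc2)c(C(F)(F)F)n1` differs from compound 3 in one place: carboxymethoxy in place of (methylsulfonyl)carbamoyl on an aromatic carbon. Among the compounds with values here, only one measured step bears on this, a number 5 percentage points lower from compound 1 to compound 2 (within the scatter), which also altered the group carried on that nitrogen and stayed within the scatter. Within the data shown here, no compound with a carboxymethoxy group has been measured, so the expectation rests on that single step. The step of a number 5 percentage points lower from compound 3 to compound 4 (within the scatter) is expected to stay within the scatter. Compound 4 is estimated at 62%, with a range from 48% to 76%.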

Compound 4, largest response reached (reported as efficacy), in percent of the reference or control that the assay uses: 59%
Compound 4: middle estimate off by 3 percentage points, on the high side; low and high end bracket the measured number.
By their numbers in this assay, from the lowest: compounds 2, 4, 1 and 3 (each within the scatter of the next).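

In this assay, the aromatic carbon para to a large group carries carboxymethoxy in place of (methylsulfonyl)carbamoyl with a number 8 percentage points lower from compound 3 to compound 4 (within the scatter), so this exchange of groups does not separate the two compounds. Larger changes on the nitrogen read the same way: replacing 3-carboxyphenyl with 4-(carboxymethoxy)phenyl gives a number 1 percentage points higher from compound 2 to compound 4 (within the scatter), and replacing (4-carboxyphenyl)carbonyl with 4-(carboxymethoxy)benzyl gives a number 4 percentage points lower from compound 1 to compound 4 (within the scatter). No available measurement explains why the response stays so close across these changes.

From the compounds shown here alone, each of the four compounds carries either a carboxylic acid or (methylsulfonyl)carbamoyl, so it remains open how an amine or a nitrile in that place would compare. Also open, going by these compounds, is whether a longer chain than carboxymethoxy on the same aromatic carbon would stay within the scatter of compound 3.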